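The source may hold more compounds than are shown below. What is called first, only, known or untested is meant among the compounds shown, and "the series" means these compounds.

In an assay on isolated protein for inhibition of microsomal triglyceride transfer protein large subunit (Homo sapiens) (a lower number here means a stronger inhibitor, a higher number a weaker inhibitor), compound 1 `Cc1cccc(C(=O)Nc2ccc3c(c2)CC(NS(=O)(=O)c2ccccc2)C3)c1-c1ccc(F)cc1` gives 240 nM. Compound 2 `Cc1cccc(C(=O)Nc2ccc3c(c2)CC(NS(=O)(=O)c2ccccc2)C3)c1-c1ccc(C#N)cc1` gives 120 nM. Compound 3 `Cc1cccc(C(=O)Nc2ccc3c(c2)CC(NS(=O)(=O)c2ccccc2)C3)c1-c1ccc(Cl)cc1` gives 100 nM.

Compound 1 has the highest number of the three: the step of a 2.0-fold lower number from compound 1 to compound 2 (0.30 log units; within the scatter) stays within the scatter, the step of a 2.4-fold lower number from compound 1 to compound 3 (0.38 log units; beyond the scatter) is modest but beyond it, and the step of a 1.2-fold lower number from compound 2 to compound 3 (0.08 log units; within the scatter) is within the scatter. Compound 4 `Cc1cccc(C(=O)Nc2ccc3c(c2)CC(NS(=O)(=O)c2cccs2)C3)c1-c1ccc(F)cc1` differs from compound 1 by thiophen-2-yl in place of phenyl on a sulfonyl sulfur. Among the measured compounds shown here, none of the measured steps bears on this change; all three concern a substituent on an aromatic carbon elsewhere in the shared core, and the sulfonyl part is unchanged throughout. With no guide from the measured set, no step beyond the scatter is expected, the expected step being no change at the digits printed from compound 1 to compound 4 (within the scatter), and the range is kept wide. Compound 4 is estimated at 240 nM, between 80 nM and 720 nM.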

Compound 4, half-maximal inhibitory concentration: 50 nM
Estimate against measurement, compound 4: 4.8-fold (0.68 log units) above, outside the stated range (below it).
By their numbers in this assay, from the lowest: compounds 4, 3, 2 and 1 (each within the scatter of the next, the first and the last beyond it).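

Among the compounds shown here, the sulfonyl part, unchanged across the earlier compounds, is not a fixed feature of the series: in this assay, thiophen-2-yl in place of phenyl on the sulfonyl sulfur gives a 4.8-fold lower number from compound 1 to compound 4 (0.68 log units; beyond the scatter) with the fluoro substituent held constant. This single pair shows that the position responds to a change of ring, but no measurement offered here accounts for the step.

Going by these compounds, whether the step carries over to the chloro and cyano substituents of compound 3 and compound 2 remains open. So does the reading for thiophen-3-yl, furan-2-yl or a plain methyl on the sulfonyl sulfur.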